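The compounds below may be only part of what the source reports. "The series", "measured", "known", "first", "only" and "open" are said of these compounds alone.

In a functional assay on MCF7 cells (Homo sapiens) for inhibition (a higher number here means a weaker inhibitor, a lower number a stronger inhibitor), compound 2 `O=C(O)COc1ccc(C(=O)/C=C/c2ccc(Cl)c(Cl)c2)cc1` gives 13000 nM, the highest of the three numbers at hand. Compound 3 `O=C(/C=C/c1ccc(F)c(Br)c1)c1ccc(B(O)O)cc1` gives 8500 nM, within the scatter of that, while compound 1 `O=C(/C=C/c1ccc(F)c(Cl)c1)c1ccc(B(O)O)cc1` gives 6000 nM, lower by more than the scatter. Compound 4 `O=C(/C=C/c1ccc(Cl)c(Cl)c1)c1ccc(B(O)O)cc1` differs from compound 2 in one place: a group of 3 heavy atoms (1 boron, 2 oxygen; no ring) in place of a group of 5 heavy atoms (2 carbon, 3 oxygen; no ring), on an aromatic carbon. Among the compounds with values here, no measured step covers this exchange; the only one available, a 1.4-fold higher number from compound 1 to compound 3 (0.15 log units; within the scatter), is a halogen swap and does not bear on it. The entering group is already present in compound 1 at 6000 nM and in compound 3 at 8500 nM. A modest fall in this assay is therefore expected, a 1.9-fold lower number from compound 2 to compound 4 (0.27 log units; within the scatter). Compound 4 is estimated at 7000 nM, with a range from 3000 nM to 16000 nM.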

Compound 4, half-maximal inhibitory concentration: 5000 nM
For compound 4 the middle estimate is 1.4-fold (0.15 log units) above the measured one; the measured number falls inside the stated range.
By their numbers in this assay, from the lowest: compounds 4, 1, 3 and 2 (each within the scatter of the next, the first and the last beyond it).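

In this assay, within the data shown here, the boron-bearing group in place of carboxymethoxy on this aromatic carbon gives a 2.6-fold lower number from compound 2 to compound 4 (0.41 log units; beyond the scatter) and so is the first exchange at this position to be read, and it lies beyond the scatter. The other new step, a 1.2-fold lower number from compound 1 to compound 4 (0.08 log units; within the scatter) with chloro in place of fluoro, stays within the scatter, so this halogen exchange shows no clear change. Nothing at hand gives a reason for the difference between these two groups.

From the compounds shown here alone, only these two groups can be compared at this position, so it remains open how an amine or a nitrile there would compare.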